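The compounds below may be only part of what the source reports. "The series", "measured", "known", "first", "only" and "open" are said of these compounds alone.

In a functional assay on HT-29 cells (Homo sapiens) for antiproliferative activity, read by MTT assay, with a stated time of 72 h (a higher number here means a weaker inhibitor, a lower number a stronger inhibitor), compound 1 `C=CC(=O)Nc1nc(-c2ccccc2)cs1` gives 6600 nM, the middle of three numbers and within the scatter of both others. Compound 2 `C=CC(=O)Nc1nc(-c2ccc(C(F)(F)F)cc2)cs1` gives 4000 nM, and compound 3 `C=CC(=O)Nc1nc(-c2ccc(OC)cc2)cs1` gives 12000 nM. Compound 4 `C=CC(=O)Nc1nc(-c2ccccc2OC)cs1` differs from compound 1 by methoxy in place of hydrogen on an aromatic carbon, ortho to a large group. Among the compounds with values here, the nearest precedent is a 1.8-fold higher number from compound 1 to compound 3 (0.26 log units; within the scatter), where methoxy also enters, though at another place. Trifluoromethyl gives a 1.7-fold lower number from compound 1 to compound 2 (0.22 log units; within the scatter), while a 3.0-fold higher number from compound 2 to compound 3 (0.48 log units; beyond the scatter) is the only step beyond the scatter. Within the data shown here, no measured compound has a group at this place, so little is known directly. The expected change is a 1.4-fold higher number from compound 1 to compound 4 (0.13 log units; within the scatter), which would not clearly exceed the scatter. For compound 4 the estimate is 9000 nM, with an expected range of 3500 nM to 22000 nM.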

Compound 4, half-maximal inhibitory concentration: > 30000 nM
Compound 4 gave a limit, no number; the forecaster's own chance of this, stated with the estimate: 3%; at least 3.3-fold (0.52 log units) between middle value and limit.
By their numbers in this assay, from the lowest: compounds 2, 1 and 3 (each within the scatter of the next, the first and the last beyond it). At a limit, above all of these: compound 4.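

Compound 4 stands at a limit, not at a number, in this assay: the limit of > 30000 nM in this assay, at which 1 of the 4 values shown sits. Methoxy in place of hydrogen, ortho to a large group, gives an at least 4.5-fold higher number from compound 1 to compound 4 (0.65 log units; beyond the scatter), the first step from compound 1 that lies beyond the scatter. Methoxy entering at the other place gives only a 1.8-fold higher number from compound 1 to compound 3 (0.26 log units; within the scatter), so in this series the outcome of the same change depends on where the group sits.

The compounds shown leave open whether a fluorine, a hydroxyl or an amine at this position would also raise the number. As far as these compounds go, how far the true value of compound 4 lies past its limit also stays open.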